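Five-membered ring in place of pyridin-4-yl

This account rests on a few compounds, and the source may have more. Where it says the series, first, only, none or still open, it means among the compounds named here.

Measured so far:
compound 1 `Cn1nc2c(=O)n(CC3(O)CCN(Cc4ccc(-c5ccco5)cc4Cl)CC3)cnc2c1-c1ccc(F)cc1` gives 64.5 nM in an assay on isolated protein for inhibition of ubiquitin carboxyl-terminal hydrolase 7 (Homo sapiens), with stated times of 30 min and 2 h; on this read-out lower numbers stand for stronger inhibition and higher numbers for weaker inhibition
compound 2 `Cn1nc2c(=O)n(CC3(O)CCN(Cc4ccc(-c5ccncc5)cc4Cl)CC3)cnc2c1-c1ccc(CN)cc1` gives 257 nM in this assay

Compound 2 holds the higher of the two numbers, and its gap to compound 1 lies beyond the scatter. Compound 3 `Cn1nc2c(=O)n(CC3(O)CCN(Cc4ccc(-c5ncco5)cc4Cl)CC3)cnc2c1-c1ccc(CN)cc1` differs from compound 2 in one place: 1,3-oxazol-2-yl in place of pyridin-4-yl on an aromatic carbon. Going by the values given here, no measured pair carries this change, so no step can be drawn from the data. The expectation for a 1.0-fold lower number from compound 2 to compound 3 (0.01 log units; within the scatter) is a step too small to separate from the scatter, in no firm direction. Compound 3 is therefore estimated at 250 nM in this assay, within 100 nM to 600 nM.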

Compound 3, half-maximal inhibitory concentration: 1120 nM
Estimate against measurement, compound 3: 4.5-fold (0.65 log units) below; the whole stated range lies below it.
By their numbers in this assay, from the lowest: compound 1; then compound 2; then compound 3.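

In this assay 1,3-oxazol-2-yl in place of pyridin-4-yl, para to a large group, brings a 4.4-fold higher number from compound 2 to compound 3 (0.64 log units; beyond the scatter) and shows that this position responds to the ring it carries. The change alters ring size and hetero atom count together, so the step cannot be assigned to either alone. Nothing measured here bears on the reason for this step.

Open, going by these compounds, is whether a plain phenyl or a 1,3-thiazol-2-yl ring at this position, with the rest of compound 2 kept, would separate these two features.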